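A few compounds are considered here, and "the series" means these few. Any claim that something is new, unique, unknown or untested is made for them only; others in the source may bear on it.

In a functional assay on the whole organism (strain STD-ddY) for inhibition, with Mus musculus as the target, with a stated time of 5 min (on this read-out higher numbers stand for an effect only at larger amounts of compound and lower numbers for an effect already at smaller amounts), compound 2 `CSc1nc2ccccc2n1C1CCN(CCCC(=O)c2ccc(F)cc2)CC1` gives 6.2 mg/kg. Among the compounds with values here, this is the only real number among the values shown; the other value is a limit. Compound 1 `O=C(CCCN1CCC(n2c(C(F)(F)F)nc3ccccc32)CC1)c1ccc(F)cc1` gives > 40 mg/kg in this assay, which is a limit of the assay and not a number. Within the data shown here, the one measured step, an at least 6.4-fold lower number from compound 1 to compound 2 (0.80 log units; beyond the scatter), concerns the group on the aromatic carbon, and because the limit of > 40 mg/kg in this assay, at which 1 of the 2 values shown sits, caps the value of compound 1, only its minimum size is known. Compound 3 `O=C(CCCN1CCC(n2c(SCCO)nc3ccccc32)CC1)c1ccc(F)cc1` differs from compound 2 by hydroxymethyl in place of hydrogen on a saturated chain carbon bound to a sulfur. Among the measured compounds shown here, this change sits on the chain carbon bound to a sulfur, a different place from the measured step, so no measured step bears on it. The expected step, a 1.3-fold higher number from compound 2 to compound 3 (0.11 log units; within the scatter), is therefore no larger than the usual scatter. Compound 3 is expected to give 8 mg/kg in this assay, within a range from 3 mg/kg to 25 mg/kg.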

Compound 3, dose for half-maximal effect: 6.9 mg/kg
For compound 3 the middle estimate is 1.2-fold (0.06 log units) above the measured one; the measured number falls inside the stated range.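

In this assay, replacing methylsulfanyl with (2-hydroxyethyl)sulfanyl gives a 1.1-fold higher number from compound 2 to compound 3 (0.05 log units; within the scatter), so a 2-hydroxyethyl chain with its hydroxyl is tolerated here without a readable change. The second sulfur-linked group also stands clearly apart from trifluoromethyl, with an at least 5.7-fold lower number from compound 1 to compound 3 (0.76 log units; beyond the scatter), which means the earlier difference is not confined to methylsulfanyl. Only the minimum size of this step is known, since compound 1 sits at a limit of the assay: the limit of > 40 mg/kg in this assay, at which 1 of the 3 values shown sits.

As far as these compounds go, whether the sulfur itself matters remains open, and a methoxy group or an amine such as methylamino in place of methylsulfanyl would test this. From the compounds shown here alone, it is also open how much more change this group can take, for example a longer chain, or a carboxylic acid in place of the hydroxyl.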